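This account rests on a few compounds, and the source may have more. Where it says the series, first, only, none or still open, it means among the compounds named here.

Within the data shown here, in a functional assay on the whole organism for inhibition, with Cavia porcellus as the target (a lower number here means that less compound is needed, a higher number that more compound is needed for the effect), three compounds have numbers so far. Compound 1 `CCOC(=O)c1c(C)nc2cnccn12` gives 19 nM in this test, compound 2 `CCOC(=O)c1[nH]c2nccnc2c1C` gives 24 nM in it, and compound 3 `Brc1cncc2nccn12` gives 18 nM in it. These values lie within the scatter of one another, so compound 3 stands level with the other two and no ranking can be read from them.

The next compound is compound 4 `CCOC(=O)c1cn2c(Br)cncc2n1` and it is built from compound 3 by a single change (ethoxycarbonyl in place of hydrogen on an aromatic carbon) that puts ethoxycarbonyl in place of hydrogen on an aromatic carbon. Among the measured compounds shown here, no pair of measured compounds shows a change of this kind on its own, so the size of the step has no direct precedent. Ethoxycarbonyl does occur in compound 1 at 19 nM and in compound 2 at 24 nM on differing cores, and neither number stands apart from that of compound 3, which lacks the group.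

In this assay no step beyond the usual scatter is therefore expected, and the estimated step is a 1.2-fold higher number from compound 3 to compound 4 (0.09 log units; within the scatter) with no firm direction. Compound 4 is expected at 22 nM (estimated range 7 nM to 70 nM).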

Compound 4, concentration for half-maximal effect: 52 nM
For compound 4 the middle estimate is 2.4-fold (0.37 log units) below the measured one; the range from low to high includes it.
By their numbers in this assay, from the lowest: compounds 3, 1 and 2 (each within the scatter of the next); then compound 4.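

In this assay, among these compounds, ethoxycarbonyl in place of hydrogen on an aromatic carbon gives a 2.9-fold higher number from compound 3 to compound 4 (0.46 log units; beyond the scatter) and so provides the first direct reading of this change alone: a modest step beyond the scatter, toward needing more compound. Compounds 1 and 2 also carry ethoxycarbonyl, but each differs from compound 3 in more than one place, so they could not isolate the effect of adding it to this position, on the five-membered aromatic ring with 2 nitrogen. The group does not remove the effect, since compound 4 still gives 52 nM in this test, but nothing measured here explains why the number rises.

As far as these compounds go, it remains open whether a carboxylic acid, a primary amide or a methyl ester at this same carbon would give a smaller step, a larger one or one in the other direction. It is also unknown whether ethoxycarbonyl would produce a similar step if the bromine of compound 3 were replaced by chlorine or on a different core, as a single pair cannot establish a general pattern.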